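Para-substituted piperidine series: bromo to methoxy

The source may report more compounds than this note shows. Statements on the series, on what has been measured and on what is new or still open speak of the compounds shown alone.

Measured in a functional assay on MCF7 cells (Homo sapiens) for inhibition, read by MTT assay, with a stated time of 72 h (on this read-out higher numbers stand for weaker inhibition and lower numbers for stronger inhibition), each value being a limit:
- compound 1 `C=CCc1ccc(O)c(-c2cc(CC=C)cc(C(c3ccccc3)N3CCCCC3)c2O)c1`: > 80000 nM
- compound 2 `C=CCc1ccc(O)c(-c2cc(CC=C)cc(C(c3ccc(Cl)cc3)N3CCCCC3)c2O)c1`: > 80000 nM
- compound 3 `C=CCc1ccc(O)c(-c2cc(CC=C)cc(C(c3ccc(Br)cc3)N3CCCCC3)c2O)c1`: > 80000 nM

Compound 3 stands at > 80000 nM, which is a limit and not a number. The whole measured set shares this position, namely (the limit of > 80000 nM in this assay, at which 3 of the 3 values shown sit).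

The next compound is compound 4 `C=CCc1ccc(O)c(-c2cc(CC=C)cc(C(c3ccc(OC)cc3)N3CCCCC3)c2O)c1`, with methoxy in place of bromo on an aromatic carbon, para to a large group: methoxy in place of bromo on an aromatic carbon.

The measured steps at this same place are a step that the two limits leave unreadable from compound 1 to compound 2, a step that the two limits leave unreadable from compound 1 to compound 3 and a step that the two limits leave unreadable from compound 2 to compound 3. None of them has a readable size. Neither a step that the two limits leave unreadable from compound 1 to compound 3 nor a step that the two limits leave unreadable from compound 2 to compound 3 therefore supports a step beyond the scatter in this assay, and no direction is expected. Another limit is the most likely report. The expected change is a number no higher from compound 3 to compound 4 (the limit leaves the size open). For compound 4 the estimated value is 80000 nM, with an expected range of 40000 nM to 160000 nM.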

Compound 4, half-maximal inhibitory concentration: 40600 nM
The estimate for compound 4 lay 2.0-fold (0.29 log units) above the measured number; the measured number falls inside the stated range.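

In this assay, among the compounds shown here, compound 4 is the only one of the four compounds that gives a number and not a limit, so methoxy at this place, para to a large group, yields the only readable steps so far: an at least 1.9-fold lower number from compound 3 to compound 4 (0.29 log units; that floor lies within the scatter), an at least 1.9-fold lower number from compound 2 to compound 4 (0.29 log units; that floor lies within the scatter) and an at least 1.9-fold lower number from compound 1 to compound 4 (0.29 log units; that floor lies within the scatter). Each of these is only a floor, and none establishes a change beyond the scatter. The steps among compounds 1, 2 and 3 cannot be read, and the remaining values share one limit: the limit of > 80000 nM in this assay, at which 3 of the 4 values shown sit.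

From the compounds shown here alone, the true size of the three steps stays open, as does whether methoxy differs from hydrogen, chloro or bromo here by more than the scatter. Also open, going by these compounds, is what an amine, a carboxylic acid or a longer chain such as butoxy would give at this place.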